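The compounds below may be only part of what the source reports. "The series", "measured", "known", "first", "only" and "open" are said of these compounds alone.

Measured so far:
compound 1 `CCN(CC)c1ccc2cc(C(=O)c3ccc(N4CCN(C(=O)CN5CCN(S(=O)(=O)c6ccc(C#N)cc6)CC5)CC4)cc3)oc2c1`: 8470 nM
compound 2 `CCN(CC)c1ccc2cc(C(=O)c3ccc(N4CCN(C(=O)CN5CCN(Cc6ccc(/C=C/C(=O)OC)cc6)CC5)CC4)cc3)oc2c1`: 3040 nM

Going by the values given here, only two compounds carry numbers in a functional assay on HeLa cells (Homo sapiens) for cytotoxicity, read by MTT assay, with a stated time of 48 h (on this read-out higher numbers stand for weaker inhibition and lower numbers for stronger inhibition), and both share the same core. In this assay compound 1 gives 8470 nM. Compound 2 gives 3040 nM, the lower of the two numbers, and its gap to compound 1 lies beyond the usual scatter, so compound 2 is the stronger inhibitor of the pair. Among the compounds with values here, no single-point step between measured compounds exists, so nothing is known about how much the group on the ring amine nitrogen matters.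

Compound 3 `CCN(CC)c1ccc2cc(C(=O)c3ccc(N4CCN(C(=O)CN5CCN(CC(C)=O)CC5)CC4)cc3)oc2c1` changes exactly that place: acetyl in place of 4-(2-(methoxycarbonyl)ethenyl)phenyl on a saturated chain carbon bound to an amine nitrogen in a ring. A larger aromatic group gives way to a much smaller acetyl. Within the data shown here, with no measured step of this kind to lean on, the expectation is a loss of potency of moderate size, a number higher than that of compound 2 and near that of compound 1, rather than no change. Compound 3 is estimated at 8000 nM, with a range from 3000 nM to 25000 nM. That estimate means an expected step of a 2.6-fold higher number from compound 2 to compound 3 (0.42 log units; beyond the scatter) toward weaker inhibition.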

Compound 3, half-maximal inhibitory concentration: 2760 nM
Beside the measured number, compound 3's estimate is 2.9-fold (0.46 log units) above it; measured number below the stated range.
By their numbers in this assay, from the lowest: compounds 3 and 2 (each within the scatter of the next); then compound 1.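

In this assay, swapping in acetyl for 4-(2-(methoxycarbonyl)ethenyl)phenyl on a saturated chain carbon bound to an amine nitrogen in a ring gives a 1.1-fold lower number from compound 2 to compound 3 (0.04 log units; within the scatter) and so no readable difference, which means that the 12 heavy atoms and the aromatic ring of the group that leaves are not required for a number at this level. The position is not indifferent to every change, however: 2-oxopropyl in place of (4-cyanophenyl)sulfonyl on an amine nitrogen in a ring gives a 3.1-fold lower number from compound 1 to compound 3 (0.49 log units; beyond the scatter) as a modest step, so the group on this ring nitrogen can shift the cytotoxicity read-out. No measurement available here accounts for either result.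

From the compounds shown here alone, it remains open whether a bare secondary amine, a methyl or a longer chain ending in a ketone on that ring nitrogen would stay in the range of compound 2 and compound 3. Also unresolved is whether a carboxylic acid or a primary amide in place of the acetyl would keep that range, and which part of the (4-cyanophenyl)sulfonyl group goes with the higher number of compound 1.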